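The source may report more compounds than this note shows. Statements on the series, on what has been measured and on what is new or still open speak of the compounds shown alone.

In an ADME assay on the whole organism (plasma, strain BALB/c) for pharmacokinetics, with Mus musculus as the target, at a dose of 5 mg/kg by the oral route (a higher number here means more compound in the circulation at the dose given, a lower number less compound in the circulation), compound 1 `CCCS(=O)(=O)c1ccc(C)c(C#Cc2cc(C#N)ccc2OCC(=O)O)c1` gives 1370 ng.h/mL while compound 3 `Cc1ccc(S(=O)(=O)N2CCOCC2)cc1C#Cc1cc(Cl)ccc1OCC(=O)O` gives 1230 ng.h/mL and compound 2 `CN(C)S(=O)(=O)c1ccc(F)c(C#Cc2cc(Cl)ccc2OCC(=O)O)c1` gives 4880 ng.h/mL as the highest of the three numbers, with the gaps to both others beyond the scatter. Compound 4 `CS(=O)(=O)c1ccc(F)c(C#Cc2cc(Cl)ccc2OCC(=O)O)c1` is not yet measured. It departs from compound 2 through methyl in place of dimethylamino on a sulfonyl sulfur in a single place, the change from dimethylsulfamoyl to methylsulfonyl. Among the measured compounds shown here, no measured pair shows this change on its own, so nothing direct can be read for it. For the measured compounds named here, the expectation rests only on the spread of the numbers: compound 2 sits at the top, and with compound 1 at 1370 ng.h/mL and compound 3 at 1230 ng.h/mL as the only other numbers, a fall is judged likelier than a rise. The expected step is a 2.0-fold lower number from compound 2 to compound 4 (0.29 log units; within the scatter) as a moderate fall near the edge of the scatter. The estimated value for compound 4 is 2500 ng.h/mL with an expected range from 900 ng.h/mL to 7000 ng.h/mL for that number.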

Compound 4, area under the concentration-time curve: 3240 ng.h/mL
Beside the measured number, compound 4's estimate is 1.3-fold (0.11 log units) below it; the range from low to high includes it.
By their numbers in this assay, from the lowest: compounds 3 and 1 (each within the scatter of the next); then compounds 4 and 2 (each within the scatter of the next).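

In this assay, the series now has its first pair that differs in one place, and methyl in place of dimethylamino on a sulfonyl sulfur gives a 1.5-fold lower number from compound 2 to compound 4 (0.18 log units; within the scatter). At this position, on this fluoro and chloro substituted core, dimethylsulfamoyl and methylsulfonyl therefore cannot be told apart in this assay, so the sulfonamide nitrogen is not required to keep the read-out within the scatter of compound 2. Nothing available on these compounds accounts for this result.

The compounds shown leave open how an ethyl group, a cyclopropyl group or an unsubstituted amino group on the same sulfonyl sulfur would read in this assay. They also leave open whether the same exchange gives a similar step on the core of compound 1 or compound 3, each of which differs from compound 2 in more than one place.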